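Varying the benzyl group: from compound 2 to compound 4

A few compounds are considered here, and "the series" means these few. Any claim that something is new, unique, unknown or untested is made for them only; others in the source may bear on it.

In a functional assay on BXPC-3 cells (Homo sapiens) for inhibition, read by MTT assay, with a stated time of 72 h (on this read-out lower numbers stand for stronger inhibition of growth and higher numbers for weaker inhibition of growth), compound 2 `O=S(=O)(NCCCNCc1ccc(C(F)(F)F)cc1)c1cc(C(F)(F)F)cc(C(F)(F)F)c1` gives 1700 nM, level with compound 3 `O=S(=O)(NCCCNCc1ccc(-c2ccccc2)cc1)c1cc(C(F)(F)F)cc(C(F)(F)F)c1` at 1700 nM; together these are the lowest of the three numbers. Compound 1 `O=S(=O)(NCCNCc1cccc2ccccc12)c1cc(C(F)(F)F)cc(C(F)(F)F)c1` gives 23000 nM, a higher number beyond the scatter from compound 2. Compound 4 `COc1cccc(CNCCCNS(=O)(=O)c2cc(C(F)(F)F)cc(C(F)(F)F)c2)c1` differs from compound 2 by 3-methoxyphenyl in place of 4-(trifluoromethyl)phenyl on a saturated chain carbon bound to an amine nitrogen. Among the compounds with values here, the one measured step touching the benzyl substituent, no change at the digits printed from compound 2 to compound 3 (within the scatter), bears on this change, though it exchanges trifluoromethyl for phenyl rather than for a methoxy group. On that evidence a change of at most modest size, direction uncertain, is expected in this assay, a 1.5-fold higher number from compound 2 to compound 4 (0.17 log units; within the scatter). Compound 4 is estimated at 2500 nM, within 900 nM to 7000 nM.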

Compound 4, concentration for 50% growth inhibition: 1700 nM
For compound 4 the middle estimate is 1.5-fold (0.17 log units) above the measured one; the range from low to high includes it.
By their numbers in this assay, from the lowest: compounds 2, 3 and 4 (each within the scatter of the next); then compound 1.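

In this assay, the exchange of 4-(trifluoromethyl)phenyl for 3-methoxyphenyl on the saturated chain carbon bound to an amine nitrogen reads no change at the digits printed from compound 2 to compound 4 (within the scatter). Compound 3 had kept the trifluoromethyl group's place filled with phenyl, whereas this step removes all fluorine from the group and adds one hydrogen-bond acceptor, and the number still holds. Nothing available accounts for this flat reading.

Open, as far as these compounds go, is how a 4-methoxyphenyl group would read here, which would show whether the substituent's place on the ring matters. Also open, from the compounds shown here alone, is how a benzyl group carrying a carboxylic acid or an amine would read.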